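The source may hold more compounds than are shown below. What is called first, only, known or untested is meant among the compounds shown, and "the series" means these compounds.

Among the compounds with values here, compound 2 `CCN(CC)C(=O)CN(c1cc(Cl)ccc1N(C)C)S(=O)(=O)c1ccc(OC)c(OC)c1` gives 60 nM in a functional assay on CHO cells for inhibition of Orexin receptor type 2 (Homo sapiens), read by FLIPR and calcium flux (a higher number here means a weaker inhibitor, a lower number a stronger inhibitor), the higher of the two numbers so far; compound 1 `CCN(CC)C(=O)CN(c1cc(N(C)C)ccc1C#N)S(=O)(=O)c1ccc(OC)c(OC)c1` gives 10 nM. Within the data shown here, the only measured step, a 6.0-fold higher number from compound 1 to compound 2 (0.78 log units; beyond the scatter), bears on the change to compound 3 `CCN(CC)C(=O)CN(c1cc(N(C)C)ccc1OC)S(=O)(=O)c1ccc(OC)c(OC)c1`, which is 5-(dimethylamino)-2-methoxyphenyl in place of 5-chloro-2-(dimethylamino)phenyl on a sulfonamide nitrogen. Among the measured compounds shown here, compound 3 thus resembles compound 1 more than compound 2 in the group on the sulfonamide nitrogen, so a drop toward the number of compound 1 is expected, though no step for the methoxy itself is known. Compound 3 is therefore estimated at 20 nM (6 nM to 70 nM), a step of a 3.0-fold lower number from compound 2 to compound 3 (0.48 log units; beyond the scatter).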

Compound 3, half-maximal inhibitory concentration: 239 nM
Compound 3: the middle estimate sits 12-fold (1.08 log units) below what was measured; the measured number lies above the stated range.
By their numbers in this assay, from the lowest: compound 1; then compound 2; then compound 3.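

In this assay, methoxy in place of cyano on an aromatic carbon, with the dimethylamino group unchanged, gives a large step (a 24-fold higher number from compound 1 to compound 3 (1.38 log units; beyond the scatter)), which shows how much the number depends on the group at this place. The change from 5-chloro-2-(dimethylamino)phenyl to 5-(dimethylamino)-2-methoxyphenyl also raises the number (a 4.0-fold higher number from compound 2 to compound 3 (0.60 log units; beyond the scatter)), so sharing the 5-(dimethylamino) arrangement of compound 1 does not by itself keep the number low. Nothing available explains either step.

Going by these compounds, whether a fluoro, an ethoxy or a primary amide on that carbon would come closer to the nitrile remains open. So does whether the dimethylamino group could be replaced by a pyrrolidine or a plain hydrogen.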